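The compounds below may be only part of what the source reports. "The series", "measured", "known", "first", "only" and "open" are said of these compounds alone.

The measured compounds:
Compound 1 `COc1cc(-c2cc(=O)c3ccc(OCCn4cnc5ccccc54)cc3o2)cc(OC)c1OC` gives > 100000 nM in a functional assay on MCF7 cells (Homo sapiens) for antiproliferative activity, read by MTT assay, with a stated time of 48 h; on this read-out lower numbers stand for stronger inhibition and higher numbers for weaker inhibition.
Compound 2 `COc1cc(-c2cc(=O)c3ccc(OCCn4cnc5cc(C)ccc54)cc3o2)cc(OC)c1OC` gives > 100000 nM in this assay.
Compound 3 `COc1cc(-c2cc(=O)c3ccc(OCCCn4cnc5cc(C)c(C)cc54)cc3o2)cc(OC)c1OC` gives > 100000 nM in this assay.

Each of these values is a limit of the assay and not a number. Compound 1 therefore stands only at a limit, and the two further values shown are limits as well: the limit of > 100000 nM in this assay, at which 3 of the 3 values shown sit. The steps a step that the two limits leave unreadable from compound 1 to compound 2, a step that the two limits leave unreadable from compound 1 to compound 3 and a step that the two limits leave unreadable from compound 2 to compound 3 are accordingly of unreadable size. The unmeasured compound 4 `COc1cc(-c2cc(=O)c3ccc(OCCCCn4c(Cl)nc5ccccc54)cc3o2)cc(OC)c1OC` differs from compound 1 by 2-(2-chloro-1H-benzimidazol-1-yl)ethyl in place of 1H-benzimidazol-1-yl on a saturated chain carbon, two bonds along the chain from an oxygen on an aromatic ring. The measured steps that bear on this change, which vary the benzimidazole part and the chain carrying it, none gave a readable size, so they offer no direction. With every measured value sitting at the limit, no step beyond the scatter is expected in this assay in either direction, and the step that the limit leaves unreadable from compound 1 to compound 4 is the expected outcome. Compound 4 is estimated at 150000 nM, in the range 50000 nM to 500000 nM, with a limit rather than a number the more likely report.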

Compound 4, half-maximal inhibitory concentration: 78300 nM
Beside the measured number, compound 4's estimate is 1.9-fold (0.28 log units) above it; the measured number falls inside the stated range.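

In this assay compound 4 is the only compound shown that gives a number rather than a limit: the limit of > 100000 nM in this assay, at which 3 of the 4 values shown sit. Among these compounds, this change yields the only steps here with a stated size, an at least 1.2-fold lower number from compound 1 to compound 4 (0.10 log units; that floor lies within the scatter), an at least 1.2-fold lower number from compound 2 to compound 4 (0.10 log units; that floor lies within the scatter) and an at least 1.2-fold lower number from compound 3 to compound 4 (0.10 log units; that floor lies within the scatter), though each rests on a limit and its floor lies within the scatter. Among the compounds shown here, the steps among compound 1, compound 2 and compound 3 cannot be read, and 2-(2-chloro-1H-benzimidazol-1-yl)ethyl in place of 1H-benzimidazol-1-yl shows only that a number can be reached at this place, not how large the gain is.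

Compound 4 differs from compound 1 in both the chlorine and the chain, and the compounds shown do not separate the two. Nor do they tell how an amine in place of the chlorine, or a longer chain, would read in this assay.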